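The source may report more compounds than this note shows. Statements on the series, on what has been measured and on what is new or still open speak of the compounds shown alone.

Measured so far in a functional assay on ECa-109 cells (Homo sapiens) for inhibition, read by MTT assay, with a stated time of 72 h; on this read-out lower numbers stand for stronger inhibition and higher numbers for weaker inhibition:
compound 1 `N#Cc1c(Nc2cccc(C(F)(F)F)c2)nc(SCc2cn(Cc3ccccc3Cl)nn2)nc1-c1ccccc1`: 32000 nM
compound 2 `Cc1cccc(Nc2nc(SCc3cn(Cc4ccccc4Cl)nn3)nc(-c3ccccc3)c2C#N)c1`: 15600 nM

Going by the values given here, compound 2 holds the lower of the two numbers in this assay; the only step measured, a 2.1-fold lower number from compound 1 to compound 2 (0.31 log units; beyond the scatter), is modest and beyond the scatter. Compound 3 `N#Cc1c(Nc2cccc([N+](=O)[O-])c2)nc(SCc2cn(Cc3ccccc3Cl)nn2)nc1-c1ccccc1` differs from compound 2 by nitro in place of methyl on an aromatic carbon. Among the compounds with values here, that step touches the same aromatic carbon as the measured one, but a nitro group has no precedent here, so the direction is uncertain; a small change, if any, is expected a 1.6-fold higher number from compound 2 to compound 3 (0.20 log units; within the scatter). Compound 3 is therefore estimated at 25000 nM, within 10000 nM to 60000 nM.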

Compound 3, half-maximal inhibitory concentration: > 64000 nM
Compound 3 gave a limit, no number; the forecaster's own chance of this, stated with the estimate: 10%; middle value at least 2.5-fold (0.40 log units) from the limit.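

Compound 3 gives a limit, not a number, in this assay: the limit of > 64000 nM in this assay, at which 1 of the 3 values shown sits. Nitro in place of methyl on this aromatic carbon gives an at least 4.1-fold higher number from compound 2 to compound 3 (0.61 log units; beyond the scatter), which leaves methyl with the lowest number of the three groups shown. Nitro in place of trifluoromethyl gives an at least 2.0-fold higher number from compound 1 to compound 3 (0.30 log units; that floor lies within the scatter), so compound 3 cannot yet be separated from compound 1 beyond the scatter.

As far as these compounds go, the true value of compound 3 remains open. Also open, from the compounds shown here alone, is how an amine, a methoxy group or a chlorine on this aromatic carbon would compare with methyl.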